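The source may report more compounds than this note shows. Statements on the series, on what has been measured and on what is new or still open speak of the compounds shown alone.

Going by the values given here, in an ADME assay on MT4 cells (Homo sapiens) for cytotoxicity, read by MTT assay (a lower number here means that less compound is tolerated, a higher number that more compound is tolerated), compound 1 `Cc1cc(C)cc(S(=O)(=O)c2c(C(=O)Nc3ccncc3)[nH]c3ccc(Cl)cc23)c1` gives 20200 nM, the only actual number so far. Compound 2 `Cc1cccc(C)c1S(=O)(=O)c1c(C(=O)NCc2ccncc2)[nH]c2ccc(Cl)cc12` gives only a limit, > 55000 nM. Compound 3 `O=C(NCc1ccncc1)c1[nH]c2ccc(Cl)cc2c1S(=O)(=O)c1c(Cl)cccc1Cl` also gives only a limit, > 50200 nM.

Compound 4 `Cc1cc(C)cc(S(=O)(=O)c2c(C(=O)NNc3ccncc3)[nH]c3ccc(Cl)cc23)c1` keeps the rest of compound 1 and carries (pyridin-4-yl)amino in place of pyridin-4-yl on an amide-type nitrogen.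

Among the compounds with values here, the one measured step, a step that the two limits leave unreadable from compound 2 to compound 3, lies on a sulfonyl sulfur rather than on the amide-type nitrogen, and it has no readable size. Within the data shown here, no measured step therefore speaks directly to this change, and the expectation for this assay stays anchored on compound 1 at 20200 nM. The expected step is a 1.1-fold lower number from compound 1 to compound 4 (0.05 log units; within the scatter), with no shift beyond the scatter foreseen, although the uncertainty is wide in both directions. For compound 4 the estimated value is 18000 nM, with an expected range of 6000 nM to 50000 nM.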

Compound 4, half-maximal cytotoxic concentration: 30300 nM
Beside the measured number, compound 4's estimate is 1.7-fold (0.23 log units) below it; the measured number falls inside the stated range.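

In this assay, going by these compounds alone, the amide-type nitrogen takes (pyridin-4-yl)amino in place of pyridin-4-yl with a 1.5-fold higher number from compound 1 to compound 4 (0.18 log units; within the scatter), the first readable step, as the values of compound 2 and compound 3 are both limits and the step between them cannot be read. At this place, then, a group that carries a hydrogen-bond donor, which pyridin-4-yl lacks, leaves compound 4 within the scatter of compound 1. No measurement shown here bears on why the two values sit so close.

Going by these compounds, whether a carboxylic acid or a morpholine on the same amide-type nitrogen would give a step beyond the scatter remains open. Also open, on these data alone, is whether a longer chain of nitrogen atoms, such as ((pyridin-4-yl)amino)amino, would stay within it.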